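The source may hold more compounds than are shown below. What is called first, only, known or untested is meant among the compounds shown, and "the series" means these compounds.

Working notes on the series, measured in a functional assay on MCF7 cells (Homo sapiens) for antiproliferative activity, read by MTT assay, with a stated time of 48 h; on this read-out lower numbers stand for stronger inhibition and higher numbers for weaker inhibition:

- compound 1 `COc1ccc(C2OC(c3ccc4ccccc4c3)=NN2C(C)=O)cc1`: 7.35 ug/mL
- compound 2 `CC(=O)N1N=C(c2ccc3ccccc3c2)OC1c1ccccc1Br`: 5.49 ug/mL
- compound 3 `CC(=O)N1N=C(c2ccc3ccccc3c2)OC1c1ccc(F)cc1`: 3.02 ug/mL

Compound 3 gives 3.02 ug/mL, the lowest of the three numbers, but it is separated clearly on one side only. The measured steps to it are a 2.4-fold lower number from compound 1 to compound 3 (0.39 log units; beyond the scatter) and a 1.8-fold lower number from compound 2 to compound 3 (0.26 log units; within the scatter).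

The change under consideration leads to compound 4 `CC(=O)N1N=C(c2ccc3ccccc3c2)OC1c1cccnc1`, which carries pyridin-3-yl in place of 4-fluorophenyl on a saturated ring carbon.

Among the compounds with values here, three measured steps bear on this, since all of them exchange the aromatic group on that carbon. Besides the two above, there is a 1.3-fold lower number from compound 1 to compound 2 (0.13 log units; within the scatter). Within the data shown here, only the step to compound 3 leaves the scatter, and it is modest. Among the measured compounds shown here, no measured compound has a ring nitrogen in this group, so the data do not fix the direction. A move towards the other two numbers is the more likely one, as compound 3 sits at the low end of this assay with its 3.02 ug/mL. The expected change is small: a 1.7-fold higher number from compound 3 to compound 4 (0.22 log units; within the scatter). For compound 4 the estimated value is 5 ug/mL, with an expected range from 2.4 ug/mL to 10.5 ug/mL.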

Compound 4, half-maximal inhibitory concentration: 2.61 ug/mL
Compound 4: middle estimate off by 1.9-fold (0.28 log units), on the high side, within the range that was stated.
By their numbers in this assay, from the lowest: compounds 4, 3, 2 and 1 (each within the scatter of the next, the first and the last beyond it).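

In this assay, the exchange of 4-fluorophenyl for pyridin-3-yl on the saturated ring carbon gives a 1.2-fold lower number from compound 3 to compound 4 (0.06 log units; within the scatter) and so does not separate the two groups, even though the entering ring carries a ring nitrogen and is counted with one hydrogen-bond acceptor where the leaving ring has none. Pyridin-3-yl is also separated from the other two aromatic groups, with a 2.1-fold lower number from compound 2 to compound 4 (0.32 log units; beyond the scatter) and a 2.8-fold lower number from compound 1 to compound 4 (0.45 log units; beyond the scatter), both modest steps, whereas 4-fluorophenyl in compound 3 leaves the scatter only against compound 1. This position therefore admits an aromatic ring with a hetero atom without loss in this read-out, but nothing measured on either group accounts for this.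

The compounds shown leave open whether the placing of the ring nitrogen matters, since pyridin-3-yl is the only such ring here, and whether a carboxylic acid or an amine on the aromatic ring would be accommodated at this carbon. As far as these compounds go, the acetyl group is also common to all four compounds, so the effect of a longer acyl chain in its place remains unknown.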